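The compounds below may be only part of what the source reports. "The series", "measured", "known", "first", "only" and "open" are said of these compounds alone.

Compound 1 (`COc1cc(-c2ccnc3cc(-c4ccc(Cl)cc4)nn23)cc(OC)c1OC`), compound 2 (`COc1cc(-c2ccnc3cc(-c4ccc(C(F)(F)F)cc4)nn23)cc(OC)c1OC`) and compound 3 (`COc1cc(-c2ccnc3cc(-c4ccc(C(C)=O)cc4)nn23)cc(OC)c1OC`) share one core and differ in a single group. In a functional assay on A549 cells (Homo sapiens) for inhibition, read by CCK-8 assay, with a stated time of 48 h (a lower number here means a stronger inhibitor, a higher number a weaker inhibitor), their readings are close: compound 1 (3070 nM), compound 2 (2070 nM) and compound 3 (4100 nM). Compound 3 therefore stands within the usual scatter of both other compounds, and the three cannot be ranked. Each swap among them stays within that scatter: trifluoromethyl in place of chloro (a 1.5-fold lower number from compound 1 to compound 2 (0.17 log units; within the scatter)), acetyl in place of chloro (a 1.3-fold higher number from compound 1 to compound 3 (0.13 log units; within the scatter)) and acetyl in place of trifluoromethyl (a 2.0-fold higher number from compound 2 to compound 3 (0.30 log units; within the scatter)).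

Compound 4 (`COc1cc(-c2ccnc3cc(-c4ccc5cnn(C)c5c4)nn23)cc(OC)c1OC`) goes further, with 1-methyl-1H-indazol-6-yl in place of 4-acetylphenyl on an aromatic carbon. The three measured steps exchanged only a small group on a ring that stayed in place, whereas here the whole group changes and two fused aromatic rings enter. Those steps therefore bear on this change only weakly. Going by the values given here, no measured compound carries such a group, so the direction is a judgement and not a reading. In this assay the expected move is downward, an estimated step (a 5.1-fold lower number from compound 3 to compound 4 (0.71 log units; beyond the scatter)) beyond the scatter but uncertain in size. Compound 4 is expected at 800 nM within an estimated range of 60 nM to 4500 nM overall.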

Compound 4, half-maximal inhibitory concentration: 233 nM
Compound 4: middle estimate off by 3.4-fold (0.54 log units), on the high side; measured number inside the range.
By their numbers in this assay, from the lowest: compound 4; then compounds 2, 1 and 3 (each within the scatter of the next).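

In this assay, going by these compounds alone, the place on the shared core, an aromatic carbon of a five-membered aromatic ring with 2 nitrogen, proves able to give a clear change in the number, something the small swaps on the phenyl ring never did within the earlier compounds. Putting 1-methyl-1H-indazol-6-yl there in place of 4-acetylphenyl gives an 18-fold lower number from compound 3 to compound 4 (1.25 log units; beyond the scatter), in place of 4-chlorophenyl it gives a 13-fold lower number from compound 1 to compound 4 (1.12 log units; beyond the scatter), and in place of 4-(trifluoromethyl)phenyl it gives an 8.9-fold lower number from compound 2 to compound 4 (0.95 log units; beyond the scatter), so the gain holds against all three phenyl compounds. Nothing available here accounts for this gain through any measured property of the new group.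

The compounds shown leave open which part of 1-methyl-1H-indazol-6-yl carries the gain: the methyl, the ring nitrogens, or simply the second fused ring. They also leave open whether another group at this place would hold or lose this level, for example a phenyl ring bearing an amine or a carboxylic acid, or the same fused rings without the methyl.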